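Adding an isobutoxy group to the benzamide of compound 2

This account rests on a few compounds, and the source may have more. Where it says the series, first, only, none or still open, it means among the compounds named here.

Compound 1 `CCOc1ccc(-c2cc(C(=O)O)nn2-c2ccc(Oc3ccccc3)cc2)cc1` gives 1030 nM in an assay for displacement of a labelled ligand from E3 ubiquitin-protein ligase Mdm2 (Homo sapiens), read by fluorescence polarization, with a stated time of 30 min; on this read-out lower numbers stand for stronger inhibition and higher numbers for weaker inhibition. Among the compounds with values here, compound 2 `CCOc1ccc(-c2c(NC(=O)c3ccccc3)c(C(=O)O)nn2-c2ccc(Oc3ccccc3)cc2)cc1` carries a benzamido group and gives 1130 nM, the highest of the two numbers so far, with compound 1 nearest. Compound 3 `CCOc1ccc(-c2c(NC(=O)c3ccc(OCC(C)C)cc3)c(C(=O)O)nn2-c2ccc(Oc3ccccc3)cc2)cc1` differs from compound 2 by isobutoxy in place of hydrogen on an aromatic carbon. Within the data shown here, the only measured step, a 1.1-fold higher number from compound 1 to compound 2 (0.04 log units; within the scatter), built the benzamide itself and changed little; no step yet probes substitution on that benzamide, so only a modest shift is expected, a 1.4-fold lower number from compound 2 to compound 3 (0.15 log units; within the scatter). Compound 3 is therefore expected to give about 800 nM, within roughly 300 nM to 2500 nM.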

Compound 3, inhibition constant: 446 nM
Compound 3: middle estimate off by 1.8-fold (0.25 log units), on the high side; the measured number falls inside the stated range.
By their numbers in this assay, from the lowest: compound 3; then compounds 1 and 2 (each within the scatter of the next).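

In this assay, isobutoxy on the phenyl of the benzamide, para to a large group, gives a 2.5-fold lower number from compound 2 to compound 3 (0.40 log units; beyond the scatter). Unlike the step that added the benzamido group, this one lies beyond the scatter, so the outer ring of the benzamide is a place where a substituent can change the number. Nothing measured here explains the change. Still open, as far as these compounds go, is whether a methoxy group, a longer chain or an amine at the same place would lower the number further. Also open, from the compounds shown here alone, is how isobutoxy would behave elsewhere on this ring.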